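A carbamate swap on a shared scaffold

The compounds below may be only part of what the source reports. "The series", "measured", "known", "first", "only" and "open" are said of these compounds alone.

Of the compounds shown here, two with one shared core have been tested in a functional assay on PANC-1 cells (Homo sapiens) for inhibition, read by MTT assay, with a stated time of 24 h, tested at 10 uM; on this read-out higher numbers stand for more inhibition at the one concentration tested (going by the name of the read-out) and lower numbers for less inhibition. Compound 1 `CC(C)=CCC1Cc2c(O)cc(=O)n(CCCO)c2CC1(C)C` carries a free hydroxyl group on its aromatic ring and in this assay gives 25.6%. Compound 2 `COc1ccc(NC(=O)Oc2cc(=O)n(CCCO)c3c2CC(CC=C(C)C)C(C)(C)C3)cc1` has a (4-methoxyphenyl)carbamoyl group in place of that hydrogen on the oxygen, and in this assay compound 2 gives 3.7%. Among the compounds with values here, the only measured step, a number 21.9 percentage points lower from compound 1 to compound 2 (beyond the scatter), is therefore a modest loss. On these two numbers compound 2 stands lowest.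

Compound 3 `CC(C)=CCC1Cc2c(OC(=O)Nc3ccccc3F)cc(=O)n(CCCO)c2CC1(C)C` keeps the carbamate but changes the group on its nitrogen: 2-fluorophenyl in place of 4-methoxyphenyl on an amide-type nitrogen. Within the data shown here, no measured step covers such a change of the aromatic group on the amide-type nitrogen; the single known step concerns adding the carbamate itself. For the move from compound 2 to compound 3 the expectation is therefore a step of no clear size beyond the scatter, written as a number 3.3 percentage points higher from compound 2 to compound 3 (within the scatter). Compound 3 is estimated to give 7% in this assay, with a plausible range from -8% to 25%.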

Compound 3, a percentage reported as inhibition, at one concentration (the size of the read-out at that concentration, not a potency): 52.3%
Estimate against measurement, compound 3: 45.3 percentage points below; the whole stated range lies below it.
By their numbers in this assay, from the lowest: compound 2; then compound 1; then compound 3.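

The group on the amide-type nitrogen turns out to matter a great deal: with 2-fluorophenyl in place of 4-methoxyphenyl, this assay shows a number 48.6 percentage points higher from compound 2 to compound 3 (beyond the scatter). The carbamate therefore does not simply lower the read-out, since the earlier step was a number 21.9 percentage points lower from compound 1 to compound 2 (beyond the scatter), whereas the 2-fluorophenyl version gives a number 26.7 percentage points higher from compound 1 to compound 3 (beyond the scatter), so the direction of the change from the free hydroxyl depends on the group the carbamate carries. Nothing available explains why these two groups differ so sharply.

The swap replaces 4-methoxyphenyl with 2-fluorophenyl as whole groups, so these three compounds cannot tell whether the gain comes from the fluorine, from the loss of the methoxy group, or from where on the ring each one sits. A plain phenyl, a 4-fluorophenyl or a 2-methoxyphenyl on that nitrogen would help to separate these possibilities, and a cyclohexyl would test whether an aromatic ring is needed there at all, while each number here, taken at a single concentration, still says nothing about potency.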